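Cyclopropyl for Butyl: An Estimate for Compound 4

This account rests on a few compounds, and the source may have more. Where it says the series, first, only, none or still open, it means among the compounds named here.

Measured compounds:
compound 1, `CCCCc1nc2ccccc2n1Cc1cc(Cl)c(O)c(Cl)c1`, 63.1 nM
compound 2, `CCCCc1nc2cccnc2n1Cc1cc(Cl)c(O)c(Cl)c1`, 63.1 nM
compound 3, `CCCCc1nc2ncccc2n1Cc1cc(Cl)c(O)c(Cl)c1`, 398 nM

In a functional assay (aorta) with Oryctolagus cuniculus as the target (a higher number here means weaker binding, a lower number tighter binding), compound 2 gives 63.1 nM, level with compound 1 at the digits shown and, with it, the lowest of the three numbers; compound 3 gives 398 nM, a higher number beyond the usual scatter. Compound 4, `Oc1c(Cl)cc(Cn2c(C3CC3)nc3cccnc32)cc1Cl`, has not been measured. It differs from compound 2 by cyclopropyl in place of butyl on an aromatic carbon. Among the measured compounds shown here, no measured pair shows this change, so no step for it is known. The expectation is a modest move toward a higher number, a 2.5-fold higher number from compound 2 to compound 4 (0.40 log units; beyond the scatter), possibly within the scatter. Compound 4 is therefore estimated at 160 nM, with a range from 40 nM to 630 nM.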

Compound 4, dissociation constant: 20 nM
Compound 4: the middle estimate sits 8.0-fold (0.90 log units) above what was measured; the measured number lies below the stated range.
By their numbers in this assay, from the lowest: compound 4; then compounds 1 and 2 (each within the scatter of the next); then compound 3.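

In this assay, the step for cyclopropyl in place of butyl on the aromatic carbon between two ring nitrogen atoms is a 3.2-fold lower number from compound 2 to compound 4 (0.50 log units; beyond the scatter), which lies beyond the scatter. The open butyl chain is therefore not required at this position, and a small three-membered ring of carbon serves there with a lower number. No available evidence bears on what lies behind this step. From the compounds shown here alone, whether the same change gives a similar step on the cores of compound 1 and compound 3 remains open. So does how ethyl, isopropyl or cyclobutyl would compare at this position.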